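Adding a Methyl to Compound 2: Cytotoxicity Outlook

This account rests on a few compounds, and the source may have more. Where it says the series, first, only, none or still open, it means among the compounds named here.

Compound 2 `Cc1nc(-c2cccnc2)sc1-c1nnc(-c2ccccc2)o1` carries a plain phenyl on the shared core. In an ADME assay on HCT-116 cells (Homo sapiens) for cytotoxicity, read by MTT assay (on this read-out lower numbers stand for higher toxicity in this test and higher numbers for lower toxicity in this test), compound 2 reaches only the limit of the test, > 100 ug/mL. Its relatives stand at the same point. In this assay compound 1 `COc1ccccc1-c1nnc(-c2sc(-c3cccnc3)nc2C)o1` gives the limit > 100 ug/mL. In this assay compound 3 `Cc1nc(-c2cccnc2)sc1-c1nnc(-c2ccccc2[N+](=O)[O-])o1` gives the limit > 100 ug/mL. Because these are limits and not numbers, the steps a step that the two limits leave unreadable from compound 1 to compound 2, a step that the two limits leave unreadable from compound 1 to compound 3 and a step that the two limits leave unreadable from compound 2 to compound 3 cannot be sized, as the limit of > 100 ug/mL in this assay, at which 3 of the 3 values shown sit, shows. Compound 4 `Cc1cccc(-c2nnc(-c3sc(-c4cccnc4)nc3C)o2)c1` differs from compound 2 by methyl in place of hydrogen on an aromatic carbon. Within the data shown here, no measured step gives a readable size for such a change. Since compound 2 itself sits at the limit > 100 ug/mL, compound 4 is expected to stay there, with a step that the limit leaves unreadable from compound 2 to compound 4 meaning no step beyond the scatter. Compound 4 is therefore estimated at 150 ug/mL, between 60 ug/mL and 400 ug/mL.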

Compound 4, half-maximal cytotoxic concentration: > 100 ug/mL
Compound 4 was reported as a limit; the forecaster's own chance of this, stated with the estimate: 85%; the middle value is on the limit's open side.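

Compound 4, like compounds 1, 2 and 3, is reported only as a limit, so no new step to compound 4 can be read: the limit of > 100 ug/mL in this assay, at which 4 of the 4 values shown sit.

The compounds shown leave open whether these four differ at all in this assay, and which change would give a readable number.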